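Chlorophenethyl variant of a thyroid receptor beta ligand

The compounds below may be only part of what the source reports. "The series", "measured", "known", "first", "only" and "open" are said of these compounds alone.

Measured compounds:
compound 1 `Cc1cc(NC(=O)CC(=O)O)c2c(c1Oc1ccc(O)c(CC(C)C)c1)CCC2` — 39.9 nM
compound 2 `Cc1cc(NC(=O)CC(=O)O)c2c(c1Oc1ccc(O)c(CCc3ccc(F)cc3)c1)CCC2` — 8.2 nM
compound 3 `Cc1cc(NC(=O)CC(=O)O)c2c(c1Oc1ccc(O)c(CCCc3ccccc3)c1)CCC2` — 223 nM

In an in vitro assay on cells for displacement of a labelled ligand from thyroid hormone receptor beta (Homo sapiens), with a stated time of 48 h (on this read-out lower numbers stand for stronger inhibition and higher numbers for weaker inhibition), compound 3 gives 223 nM, the highest number of the three; compound 1 sits a 5.6-fold higher number from compound 1 to compound 3 (0.75 log units; beyond the scatter) and compound 2 a 27-fold higher number from compound 2 to compound 3 (1.43 log units; beyond the scatter). Compound 4 `Cc1cc(NC(=O)CC(=O)O)c2c(c1Oc1ccc(O)c(CCc3cccc(Cl)c3)c1)CCC2` differs from compound 3 by 3-chlorophenyl in place of benzyl on a saturated chain carbon, two bonds along the chain from an aromatic carbon. For the measured compounds named here, the step bearing on this is the one from compound 2 to compound 3, a 27-fold higher number from compound 2 to compound 3 (1.43 log units; beyond the scatter), which compound 4 largely reverses by placing an aromatic ring at the same distance as in compound 2, though with chlorine in place of fluorine and at another ring position, which the measured set does not cover. A large lowering is therefore expected, a 15-fold lower number from compound 3 to compound 4 (1.17 log units; beyond the scatter), and compound 4 is estimated at 15 nM, with a range from 5 nM to 60 nM.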

Compound 4, inhibition constant: 41 nM
Compound 4: the middle estimate sits 2.7-fold (0.44 log units) below what was measured; the measured number falls inside the stated range.
By their numbers in this assay, from the lowest: compound 2; then compounds 1 and 4 (each within the scatter of the next); then compound 3.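

At this position, 3-chlorophenyl in place of benzyl gives a 5.4-fold lower number from compound 3 to compound 4 (0.74 log units; beyond the scatter) in this assay, but this recovers only part of the earlier loss, since 3-chlorophenyl in place of 4-fluorophenyl at the same place gives a 5.0-fold higher number from compound 2 to compound 4 (0.70 log units; beyond the scatter) on this read-out. What the ring carries therefore counts as well as how far along the chain it sits. Set against isopropyl, 3-chlorobenzyl gives a 1.0-fold higher number from compound 1 to compound 4 (0.01 log units; within the scatter) and so cannot be told apart from it.

Whether the halogen or its ring position drives the difference stays open, as neither 4-chlorophenyl nor 3-fluorophenyl stands among these compounds. Nothing shown bears on the cause of these differences.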